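Fluorine to chlorine swap on the outer ring, two cores

The source may hold more compounds than are shown below. What is called first, only, known or untested is meant among the compounds shown, and "the series" means these compounds.

Compound 1 `O=[N+]([O-])c1cc(C(F)(F)F)cc([N+](=O)[O-])c1Oc1ccc(Br)cc1/C=N\OCc1ccccc1F` and compound 2 `O=[N+]([O-])c1cc(C(F)(F)F)cc([N+](=O)[O-])c1Oc1ccc(Br)cc1/C=N/OCc1ccccc1Cl` share one core; compound 3 `O=[N+]([O-])c1cc(C(F)(F)F)cc([N+](=O)[O-])c1Oc1c(Cl)cc(Cl)cc1/C=N\OCc1ccccc1F` and compound 4 `O=[N+]([O-])c1cc(C(F)(F)F)cc([N+](=O)[O-])c1Oc1c(Cl)cc(Cl)cc1/C=N/OCc1ccccc1Cl` share another. In a functional assay on A549 cells (Homo sapiens) for antiproliferative activity, read by MTT assay, with a stated time of 48 h (a lower number here means a stronger inhibitor, a higher number a weaker inhibitor), compound 1 gives 1280 nM, and compound 2 gives 3430 nM. The change between them, (a group of 11 heavy atoms (8 carbon, 1 nitrogen, 1 oxygen, 1 chlorine; one six-membered aromatic ring of carbon only) in place of a group of 11 heavy atoms (8 carbon, 1 nitrogen, 1 oxygen, 1 fluorine; one six-membered aromatic ring of carbon only), on an aromatic carbon), produced a 2.7-fold higher number from compound 1 to compound 2 (0.43 log units; beyond the scatter). In this assay compound 3 gives 1230 nM; set against compound 1 the two values lie within the usual scatter, and the difference between the two cores is not broken down here. Compound 4 carries the same kind of change relative to compound 3, (a group of 11 heavy atoms (8 carbon, 1 nitrogen, 1 oxygen, 1 chlorine; one six-membered aromatic ring of carbon only) in place of a group of 11 heavy atoms (8 carbon, 1 nitrogen, 1 oxygen, 1 fluorine; one six-membered aromatic ring of carbon only), on an aromatic carbon); what differs around the place is that in the first pair the site is meta to a bromo group, whereas in the second pair it is meta to two chloro groups. With a single earlier instance to go on, the step from compound 3 to compound 4 in this assay is expected to be a 2.6-fold higher number from compound 3 to compound 4 (0.42 log units; beyond the scatter), resting on the earlier step of a 2.7-fold higher number from compound 1 to compound 2 (0.43 log units; beyond the scatter). Compound 4 is therefore estimated at 3200 nM, with a plausible range from 1600 nM to 6500 nM.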

Compound 4, half-maximal inhibitory concentration: 2160 nM
The estimate for compound 4 lay 1.5-fold (0.17 log units) above the measured number; low and high end bracket the measured number.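

In this assay, replacing the fluorobenzyl-type group with its chlorine counterpart on the dichloro core gives a 1.8-fold higher number from compound 3 to compound 4 (0.24 log units; within the scatter), so on this core the step alone cannot be told from scatter. Set beside the step on the bromo core, it gives no sign that the core alters the effect of this change, and the earlier step remains a workable guide for this pair of cores: the same change on two cores in this assay, a 2.7-fold higher number (0.43 log units; beyond the scatter) from compound 1 to compound 2 and a 1.8-fold higher number (0.24 log units; within the scatter) from compound 3 to compound 4, 1.5-fold (0.18 log units) apart, within the scatter of two such steps

Among these compounds, this does not establish a fixed step size or show that the change transfers to other cores, since only two pairs in one cell assay are available, and only one of the two steps lies beyond the scatter.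

The compounds shown leave open whether the same step holds when a methoxy group or an amine replaces the halogen on the outer ring. They also leave open how the change reads on a core carrying a nitrile in place of the trifluoromethyl group, or in other cell lines.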